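This account rests on a few compounds, and the source may have more. Where it says the series, first, only, none or still open, it means among the compounds named here.

Measured so far:
compound 1, `COc1ccc(C(=O)NC(=S)N2CCc3c(OCCCCCOc4ccc(Cl)cc4)cccc32)cc1`: 34400 nM
compound 2, `CC(C)(C)c1ccc(C(=O)NC(=S)N2CCc3c(OCCCCCOc4ccc(Cl)cc4)cccc32)cc1`: > 50000 nM

Both compounds share the same core and differ only in the aryl group on the carbonyl. In an ADME assay on Huh-7 cells (Homo sapiens) for cytotoxicity (on this read-out lower numbers stand for higher toxicity in this test and higher numbers for lower toxicity in this test), compound 1 gives 34400 nM. For compound 2 the read-out is a limit of this assay and not a number, > 50000 nM (the limit of > 50000 nM in this assay, at which 1 of the 2 values shown sits). Within the data shown here, the one measured step, an at least 1.4-fold higher number from compound 1 to compound 2 (0.16 log units; that floor lies within the scatter), is too small to separate the two compounds.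

Compound 3, `O=C(CCc1ccccc1)NC(=S)N1CCc2c(OCCCCCOc3ccc(Cl)cc3)cccc21`, is not yet measured in this assay. It differs from compound 2 by phenethyl in place of 4-(tert-butyl)phenyl on a carbonyl carbon. Among the measured compounds shown here, no measured step covers a change of this kind; the only step on record, tert-butyl in place of methoxy, stays within the scatter, so the series so far gives no reason to expect a shift beyond the scatter in this assay, in either direction. Compound 3 is therefore expected near 40000 nM, with a range of 15000 nM to 100000 nM. The step of an at least 1.2-fold lower number from compound 2 to compound 3 (0.09 log units; that floor lies within the scatter) is the expectation this estimate amounts to, and a further limit read-out is judged fairly likely.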

Compound 3, half-maximal cytotoxic concentration: > 50000 nM
Compound 3: only a limit was reported; the forecaster's own chance of this, stated with the estimate: 40%; middle value at least 1.2-fold (0.09 log units) away from the limit.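

In this assay compound 3 gives > 50000 nM, which is a limit of the assay and not a number. Among these compounds, the position on the carbonyl carbon now holds phenethyl as well as aryl groups, and the only readable new step is an at least 1.4-fold higher number from compound 1 to compound 3 (0.16 log units; that floor lies within the scatter), so phenethyl in place of 4-methoxyphenyl gives no separation that can be claimed, while the step between the two limit compounds, compound 2 and compound 3, cannot be read. What the change adds is that a second kind of group on this carbonyl carbon also gives no number, and the series now sits mostly at one read-out: the limit of > 50000 nM in this assay, at which 2 of the 3 values shown sit.

Still open, from the compounds shown here alone, is whether any group at this position gives a number clearly lower than compound 1 does, for instance a primary amine or a carboxylic acid on the phenethyl ring, or a longer chain in place of phenethyl. Also open, going by these compounds, is how far compound 2 and compound 3 lie past the limit, and whether changes elsewhere on the shared core move the read-out in this assay.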